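This account rests on a few compounds, and the source may have more. Where it says the series, first, only, none or still open, it means among the compounds named here.

Series notes, cytotoxicity read-out.

Within the data shown here, the two measured members share one core and differ only in the group on the aromatic nitrogen. Compound 1 `CS(=O)(=O)Nc1cccc(C(=O)N2CCCC(C(=O)Nc3ccc(Cl)cc3)C2)c1` carries a methylsulfonyl there; in an ADME assay on PC-3 cells (Homo sapiens) for cytotoxicity, read by WST assay, tested at 100 uM (on this read-out higher numbers stand for more inhibition at the one concentration tested (going by the name of the read-out) and lower numbers for less inhibition), compound 1 gives 3%. Compound 2 `CC(C)(C)CC(=O)Nc1cccc(C(=O)N2CCCC(C(=O)Nc3ccc(Cl)cc3)C2)c1` carries a neopentylcarbonyl instead; in this assay compound 2 gives 0%. The only single-point step recorded, a number 3 percentage points lower from compound 1 to compound 2 (within the scatter), is within the scatter, so on the numbers shown compound 2 sits at the low end of a pair that is effectively level: both members are essentially inactive in this assay at the single concentration tested.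

Compound 3 `O=C(Nc1ccc(Cl)cc1)C1CCCN(C(=O)c2cccc([N+](=O)[O-])c2)C1` is the next case. Relative to compound 2 the change is nitro in place of (neopentylcarbonyl)amino on an aromatic carbon. Among the measured compounds shown here, no measured step bears on this exact exchange; the one step recorded, a number 3 percentage points lower from compound 1 to compound 2 (within the scatter), shows that swapping the substituent on that aromatic position between two quite different groups left the read-out flat. For compound 3 the step of a number 3 percentage points higher from compound 2 to compound 3 (within the scatter) is therefore expected to stay within the scatter. Compound 3 is estimated at 3%, with a range of -8% to 15%, in this assay.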

Compound 3, a percentage reported as inhibition, at one concentration (the size of the read-out at that concentration, not a potency): 0%
For compound 3 the middle estimate is 3 percentage points above the measured one; the range from low to high includes it.
By their numbers in this assay, from the lowest: compounds 2, 3 and 1 (each within the scatter of the next).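

The group on this aromatic carbon can be replaced whole, not only altered on its nitrogen, without the read-out leaving the scatter: with nitro in place of (neopentylcarbonyl)amino, the record in this assay shows no change at the digits printed from compound 2 to compound 3 (within the scatter), and with nitro in place of methanesulfonamido it shows a number 3 percentage points lower from compound 1 to compound 3 (within the scatter), both on the same shared core. The earlier pair kept a substituted nitrogen at this place, whereas the nitro exchange takes the group from 8 heavy atoms to 3 and from 1 hydrogen-bond donor to 0, so neither of these counts separates the compounds on these numbers. No measurement on hand gives a reason for this result.

Among these compounds, all three compounds lie within the scatter of each other at a single concentration, so the series so far gives no handle on which features, if any, could move this read-out. As far as these compounds go, whether a primary amine, a carboxylic acid or a longer alkyl chain on this aromatic carbon, or a change elsewhere on the shared core, would give a number beyond the scatter remains open.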